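A few compounds are considered here, and "the series" means these few. Any claim that something is new, unique, unknown or untested is made for them only; others in the source may bear on it.

Working notes on the series. In a functional assay on CHO-K1 cells for antagonist activity at cysteinyl leukotriene receptor 1 (Homo sapiens), read by fluorescence and calcium flux, with stated times of 30 min and 1 h (on this read-out lower numbers stand for stronger inhibition and higher numbers for weaker inhibition), compound 2 `Cc1c(F)cccc1CCCCOc1ccc(/C=C/c2cccc3c(CCCC(=O)O)cn(CC(=O)O)c23)cc1` gives 2.9 nM, the higher of the two numbers recorded so far; compound 1 `Cc1c(F)cccc1CCCCOc1ccc(/C=C/c2cccc3c(CCCC(=O)O)c(C)n(CC(=O)O)c23)cc1` gives 1.1 nM. For the measured compounds named here, the one step between them, a 2.6-fold higher number from compound 1 to compound 2 (0.42 log units; beyond the scatter), changes the shared core and nothing else. Compound 3 `O=C(O)CCCc1cn(CC(=O)O)c2c(/C=C/c3ccc(OCCCCOc4ccccc4)cc3)cccc12` is next, and it differs from compound 2 in phenoxy in place of 3-fluoro-2-methylphenyl on a saturated chain carbon, four bonds along the chain from an oxygen on an aromatic ring. Going by the values given here, this change sits at the far end of the chain, not on the shared core, so the step between compound 1 and compound 2 offers no direct guide to it; no measured pair covers the terminal ring. The change removes a fluorine and a methyl and brings in an ether oxygen at that end, so some movement beyond the scatter is possible in either direction, with a weakening slightly more plausible. Compound 3 is therefore expected to give 6 nM in this assay, with a range from 2 nM to 20 nM. The estimated step of a 2.1-fold higher number from compound 2 to compound 3 (0.32 log units; beyond the scatter) is expected to be modest.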

Compound 3, half-maximal inhibitory concentration in the cysteinyl leukotriene receptor 1 assay: 1.5 nM
Beside the measured number, compound 3's estimate is 4.0-fold (0.60 log units) above it; the measured number lies below the stated range.
By their numbers in the cysteinyl leukotriene receptor 1 assay, from the lowest: compounds 1, 3 and 2 (each within the scatter of the next, the first and the last beyond it).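

In the cysteinyl leukotriene receptor 1 assay, a 1.9-fold lower number from compound 2 to compound 3 (0.29 log units; within the scatter), so this end of the chain accepts phenoxy in place of 3-fluoro-2-methylphenyl with no change beyond the scatter, whereas the earlier step concerned only the shared core. The fluorine and the methyl of the leaving group are therefore not needed to keep a low number here, and the oxygen that enters does no measurable harm. In a physicochemical assay for permeability, using PAMPA, with a stated time of 4 h, at pH 7.4, tested at 50 uM (on this read-out higher numbers stand for higher permeability and lower numbers for lower permeability), compound 2 gives < 0.05 10^-6 cm/s, which is a limit of the assay and not a number. In the physicochemical assay compound 3 gives < 0.05 10^-6 cm/s, which is likewise a limit of the assay and not a number. The step between them therefore cannot be read: the limit of < 0.05 10^-6 cm/s in the physicochemical assay, at which 2 of the 2 values shown sit.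

Open, on these data alone, is whether the methyl that separates compound 1 from compound 2 gives a similar step when phenoxy is present. Also open, as far as these compounds go, is how an amine or an amide in place of phenoxy would read, and whether an ester in place of a carboxylic acid would give a number rather than a limit in the physicochemical assay.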